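A few compounds are considered here, and "the series" means these few. Any claim that something is new, unique, unknown or untested is made for them only; others in the source may bear on it.

Compound 1 `COc1cc(OC)c(OC)cc1/C=C/C(=O)c1ccc(Cl)cc1`: 58500 nM
Compound 2 `COc1cc(OC)c(OC)cc1/C=C/C(=O)c1cc(OC(C)=O)ccc1OC(C)=O`: 78500 nM

Both compounds were tested in a functional assay on SW982 cells (Homo sapiens) for inhibition, read by MTT assay, with a stated time of 72 h; a lower number here means a stronger inhibitor, a higher number a weaker inhibitor. Compound 1 has the lower of the two numbers, but the gap to compound 2 lies within the usual scatter of repeated measurements, so the two cannot be ranked. For the measured compounds named here, for now, compound 1 simply stands level with the only other measured compound.

Compound 3 `COc1ccc(C(=O)/C=C/c2cc(OC)c(OC)cc2OC)cc1` has not yet been measured in this assay. It differs from compound 1 in a single place: methoxy in place of chloro on an aromatic carbon. In words, methoxy takes the place of chloro on an aromatic carbon, para to a large group, turning 4-chlorophenyl into 4-methoxyphenyl.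

Going by the values given here, no pair of measured compounds shows this change, so the data offer no direct guide to its size or direction. The one indirect hint is modest: compound 1 and compound 2 carry different groups, yet compound 2 gives 78500 nM, within the scatter of the value for compound 1. A change beyond the scatter is therefore not expected. The estimated step is a 1.1-fold higher number from compound 1 to compound 3 (0.05 log units; within the scatter). For compound 3 the expected value is 65000 nM, with an estimated range of 25000 nM to 150000 nM.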

Compound 3, half-maximal inhibitory concentration: 60500 nM
Estimate against measurement, compound 3: 1.1-fold (0.03 log units) above; the measured number falls inside the stated range.
By their numbers in this assay, from the lowest: compounds 1, 3 and 2 (each within the scatter of the next).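

At the position on an aromatic carbon para to a large group, putting methoxy in place of chloro gives, in this assay, a 1.0-fold higher number from compound 1 to compound 3 (0.01 log units; within the scatter), so this pair cannot be ranked. For the compounds shown here, this is the first direct reading of the change, and it is more informative than the earlier comparison of compound 1 with compound 2, where the two compounds carry different groups in more than one place. Here, 4-chlorophenyl and 4-methoxyphenyl differ in a single place, and although methoxy has 1 hydrogen-bond acceptor and chloro has 0, the step stays within the scatter; no independent measurement is available to explain this result.

A single pair cannot show whether this position accepts many different groups or whether these two simply happen to give matching numbers. As far as these compounds go, it remains open whether an amine, a carboxylic acid or a longer chain at this place, on the core of compound 3, would move the number beyond the scatter in either direction in this assay.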